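Swapping the Pyrazole Linkage on a Fused Core

This account rests on a few compounds, and the source may have more. Where it says the series, first, only, none or still open, it means among the compounds named here.

Three compounds have numbers in an ADME assay on microsomes from liver (Homo sapiens) for metabolic stability, read by LC-MS, using NADPH, with stated times of 5 min and 30 min, tested at 1 uM; on this read-out lower numbers stand for slow clearance and higher numbers for fast clearance:

Compound 1 `CN(c1ccn(C)n1)c1cnc(NCc2c(F)ccc3c2CCO3)c2cn[nH]c(=O)c12`: 62 mL.min-1.g-1
Compound 2 `O=C(Nc1cnc(NCc2c(F)ccc3c2CCO3)n2cnnc12)c1ccccc1`: 10 mL.min-1.g-1
Compound 3 `CC1(C)CC(=O)N(c2cnc(NCc3c(F)ccc4c3CCO4)n3cnnc23)C1`: 16 mL.min-1.g-1

Compound 1 gives the highest of the three numbers in this assay; compound 3 is the nearest to it and compound 2 the furthest, and both of those gaps are beyond the scatter. Among the measured compounds shown here, the one step between compounds that differ in a single place is a 1.6-fold higher number from compound 2 to compound 3 (0.20 log units; within the scatter), but it sits on a different core and exchanges different groups, so it offers no direct guide to what is asked here.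

Compound 4 `Cc1nn(C)cc1-c1cnc(NCc2c(F)ccc3c2CCO3)c2cn[nH]c(=O)c12` keeps the core of compound 1 and differs from it in one place: 1,3-dimethyl-1H-pyrazol-4-yl in place of methyl(1-methyl-1H-pyrazol-3-yl)amino on an aromatic carbon. For the measured compounds named here, no measured pair shows this exchange, so the expectation rests on compound 1 alone as a starting point. The author expects compound 4 to give a somewhat lower number in this assay than compound 1, though a step no larger than the scatter would not be surprising. The estimated step is a 1.6-fold lower number from compound 1 to compound 4 (0.19 log units; within the scatter). For compound 4 the estimate in this assay is 40 mL.min-1.g-1, with a range from 15 mL.min-1.g-1 to 100 mL.min-1.g-1.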

Compound 4, intrinsic clearance in microsomes: 27 mL.min-1.g-1
Estimate against measurement, compound 4: 1.5-fold (0.17 log units) above; the range from low to high includes it.
By their numbers in this assay, from the lowest: compounds 2, 3 and 4 (each within the scatter of the next, the first and the last beyond it); then compound 1.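

Among the compounds shown here, on the core of compound 1, placing 1,3-dimethyl-1H-pyrazol-4-yl in place of methyl(1-methyl-1H-pyrazol-3-yl)amino on this aromatic carbon gives a 2.3-fold lower number from compound 1 to compound 4 (0.36 log units; beyond the scatter) in this assay; the only earlier step lay on a different core and exchanged different groups, so this is the first sign that the group at this position can shift the read-out on this core. Both groups carry a five-membered aromatic ring with 2 hetero atoms, so the ring class stays the same while its linkage to the core and its methyl pattern change together, and this single step cannot separate those changes. Nothing measured here accounts for the step, and no mechanism can be assigned to it.

The compounds shown leave open whether the link to the core or the methyl pattern matters more, a question that a 1-methyl-1H-pyrazol-4-yl group or the same pyrazole joined through a plain amine could help to answer. They also leave open how a quite different group at this position, such as morpholine or phenyl, would read out, and whether this exchange would give a similar step on another core.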